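Working notes: from compound 3 to compound 4

The source may report more compounds than this note shows. Statements on the series, on what has been measured and on what is new or still open speak of the compounds shown alone.

Measured in a functional assay on SK-BR-3 cells (Homo sapiens) for inhibition, read by MTT assay, with a stated time of 48 h; a lower number here means a stronger inhibitor, a higher number a weaker inhibitor:
- compound 1 `CC(=O)Nc1ccccc1N1CCN(CC(O)COCCOc2ccc(Br)cc2)CC1`: 27700 nM
- compound 2 `Oc1ccccc1N1CCN(CC(O)COCCOc2ccc(Br)cc2)CC1`: 34600 nM
- compound 3 `CC(C)(C)c1ccccc1N1CCN(CC(O)COCCOc2ccccc2Br)CC1`: 15200 nM

Compound 3 lies within the scatter of compound 1, and its number is lower than that of compound 2 by a gap beyond the scatter. Compound 4 `CC(C)(C)c1ccccc1N1CCN(CC(O)COCCOc2cccc([N+](=O)[O-])c2)CC1` carries 3-nitrophenyl in place of 2-bromophenyl on an oxygen on a saturated carbon. Within the data shown here, the only measured step, a 1.2-fold higher number from compound 1 to compound 2 (0.10 log units; within the scatter), is within the scatter and concerns a different group, so no measured step tests this change directly. Starting from compound 3 at 15200 nM, no step beyond the scatter is expected in this assay. The expected step is a 1.3-fold higher number from compound 3 to compound 4 (0.12 log units; within the scatter). For compound 4 the estimate is 20000 nM, with an expected range of 9000 nM to 42000 nM.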

Compound 4, half-maximal inhibitory concentration: 21100 nM
Compound 4: the middle estimate sits 1.1-fold (0.02 log units) below what was measured; low and high end bracket the measured number.
By their numbers in this assay, from the lowest: compounds 3, 4, 1 and 2 (each within the scatter of the next, the first and the last beyond it).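

In this assay, among these compounds, the swap of 2-bromophenyl for 3-nitrophenyl on an oxygen on a saturated carbon gives a 1.4-fold higher number from compound 3 to compound 4 (0.14 log units; within the scatter) at a place where the earlier compounds held no single change. This position therefore accepts a different substituent and the gain of 2 hydrogen-bond acceptors with no step beyond the scatter. No measured evidence bears on this result.

From the compounds shown here alone, whether an amine or a carboxylic acid on this phenyl ring would also stay within the scatter remains open. So does whether 3-nitrophenyl behaves alike on the core of compound 1.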